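Sulfonamide series: swapping the sulfonamide nitrogen substituent

The source may report more compounds than this note shows. Statements on the series, on what has been measured and on what is new or still open speak of the compounds shown alone.

Measured compounds:
compound 1 `COc1ccc(NS(=O)(=O)c2ccc(NC(=O)c3ccc(Cl)cc3Cl)cc2)cc1` — > 100000 nM
compound 2 `O=C(Nc1ccc(S(=O)(=O)Nc2ncccn2)cc1)c1ccc(Cl)cc1Cl` — > 100000 nM

Compound 2 stands only at a limit: in a functional assay on HEK293 cells for agonist activity at probable G-protein coupled receptor 27 (Homo sapiens), read by a luciferase reporter and beta-arrestin recruitment, with a stated time of 10 min (on this read-out lower numbers stand for an effect already at smaller amounts and higher numbers for an effect only at larger amounts of compound), compound 2 gives > 100000 nM, a limit of the assay, not a number. Compound 1 likewise gives > 100000 nM in this assay, also a limit. The one step shown, a step that the two limits leave unreadable from compound 1 to compound 2, is unreadable because of the limit of > 100000 nM in this assay, at which 2 of the 2 values shown sit. The change to compound 3 `Cc1ccc(NS(=O)(=O)c2ccc(NC(=O)c3ccc(Cl)cc3Cl)cc2)cc1` is 4-methylphenyl in place of pyrimidin-2-yl on a sulfonamide nitrogen. For the measured compounds named here, no measured step bears on it with a readable size. Compound 3 is therefore expected to sit at the limit too, estimated at 200000 nM in this assay, range 50000 nM to 1000000 nM. The expected step is a step that the limit leaves unreadable from compound 2 to compound 3, beyond reading.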

Compound 3, half-maximal effective concentration: > 100000 nM
Compound 3: only a limit was reported; the forecaster's own chance of this, stated with the estimate: 90%; the middle value does not contradict the limit.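

For the compounds shown here, no step among compound 1, compound 2 and compound 3 can be read in this assay because all three stand at a limit of the assay: the limit of > 100000 nM in this assay, at which 3 of the 3 values shown sit. The compounds shown leave open whether any sulfonamide nitrogen substituent on the shared core gives a measurable effect.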